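Swapping a Propyl for Pyridine on a Weak Inhibitor

A few compounds are considered here, and "the series" means these few. Any claim that something is new, unique, unknown or untested is made for them only; others in the source may bear on it.

Of the compounds shown here, three built on the same core have been tested in an assay on Sf9 cells for inhibition of mitogen-activated protein kinase kinase kinase 14 (Homo sapiens), read by ADP-Glo, with a stated time of 60 min; on this read-out higher numbers stand for weaker inhibition and lower numbers for stronger inhibition. Compound 1 `Cc1n[nH]c(N)c1-c1ccc(Cl)cc1` gives 61100 nM in this assay. For compound 2 `Cc1[nH]nc(N)c1-c1cc(C(F)(F)F)cc(C(F)(F)F)c1` this assay reports only a limit, namely > 100000 nM. For compound 3 `CCCC(=O)n1nc(C)c(-c2ccc(Cl)c(Cl)c2)c1N` this assay likewise reports only a limit, namely > 100000 nM. Compound 3 therefore stands at the weak end of the numbers shown, sharing its limit with compound 2 as noted in the limit of > 100000 nM in this assay, at which 2 of the 3 values shown sit, while compound 1 alone has a measured number.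

Compound 4 `Cc1nn(C(=O)c2ccncc2)c(N)c1-c1ccc(Cl)c(Cl)c1` differs from compound 3 in a single place: pyridin-4-yl in place of propyl on a carbonyl carbon. The remainder of the molecule is unchanged.

Within the data shown here, no step between measured compounds involves this kind of exchange, so there is no measured guide to its size or direction. Because compound 3 sits at the limit > 100000 nM, a measurement of compound 4 can only come out stronger or again as a limit; a weaker outcome would not be visible. The expectation is a modest move at best, with a fair chance that this assay again reports only a limit. Compound 4 is expected to give about 80000 nM in this assay, plausibly between 20000 nM and 300000 nM. The expected step from compound 3 to compound 4 in this assay is an at least 1.2-fold lower number from compound 3 to compound 4 (0.09 log units; that floor lies within the scatter).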

Compound 4, half-maximal inhibitory concentration: 58200 nM
Beside the measured number, compound 4's estimate is 1.4-fold (0.14 log units) above it; low and high end bracket the measured number.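

Among these compounds, exchanging propyl for pyridin-4-yl on the carbonyl carbon yields the first measured number among the compounds with a group at this position: in this assay compound 4 gives 58200 nM as a real reading, so this place can carry a six-membered aromatic ring and still register in the assay. The exchange amounts to an at least 1.7-fold lower number from compound 3 to compound 4 (0.23 log units; that floor lies within the scatter) and no more exact size can be read from the pair. The true step could be larger than that figure, and the figure is only a floor because compound 3 carries a limit and not a number: the limit of > 100000 nM in this assay, at which 2 of the 4 values shown sit.

With a single exchange at this position, the effect of the ring cannot be separated from the effect of the nitrogen within it, and a plain phenyl on the same carbonyl carbon would be the group to settle that. On these data alone, whether a longer chain, or an amine such as morpholine, would give a clearly lower number at this place also remains open, as does whether the carbonyl group itself is needed for any reading at all.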